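Swapping a methoxy ring for a difluorinated one

A few compounds are considered here, and "the series" means these few. Any claim that something is new, unique, unknown or untested is made for them only; others in the source may bear on it.

Of the compounds shown here, three sharing one core have been tested in a functional assay on HeLa cells (Homo sapiens) for antiproliferative activity, read by MTT assay, with a stated time of 24 h; a lower number here means a stronger inhibitor, a higher number a weaker inhibitor. Compound 1 `c1ccc(CSc2nnc(-c3ccc4c(c3)OCCO4)n2-c2ccccc2)cc1` gives 32800 nM. Compound 2 `Clc1ccccc1CSc1nnc(-c2ccc3c(c2)OCCO3)n1-c1ccccc1` gives 29000 nM, and the chloro group makes little difference: a 1.1-fold lower number from compound 1 to compound 2 (0.05 log units; within the scatter).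

Compound 3 `COc1cccc(CSc2nnc(-c3ccc4c(c3)OCCO4)n2-c2ccccc2)c1` has no exact number, only a limit of the assay, > 100000 nM. This is the limit of > 100000 nM in this assay, at which 1 of the 3 values shown sits. Adding a methoxy group gives an at least 3.0-fold higher number from compound 1 to compound 3 (0.48 log units; beyond the scatter), and the comparison with the chlorinated compound gives an at least 3.4-fold higher number from compound 2 to compound 3 (0.53 log units; beyond the scatter). Both steps are minimum sizes, so the true gaps may be larger.

Compound 4 `Fc1cccc(F)c1CSc1nnc(-c2ccc3c(c2)OCCO3)n1-c1ccccc1` has 2,6-difluorophenyl in place of 3-methoxyphenyl on a saturated chain carbon bound to a sulfur. Among the compounds with values here, it therefore loses the methoxy group, the one change seen so far to give a step beyond the scatter, an at least 3.0-fold higher number from compound 1 to compound 3 (0.48 log units; beyond the scatter). Its ring instead carries halogen in place of hydrogen, as in compound 2, where that swap gave only a 1.1-fold lower number from compound 1 to compound 2 (0.05 log units; within the scatter). Within the data shown here, no fluorinated compound has been measured, so this comparison is only a rough guide. A fall back towards the two measured numbers seems likely, with an expected change of an at least 3.3-fold lower number from compound 3 to compound 4 (0.52 log units; beyond the scatter). For compound 4 the estimated value is 30000 nM, with an expected range of 12000 nM to 80000 nM.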

Compound 4, half-maximal inhibitory concentration: 35200 nM
Compound 4: middle estimate off by 1.2-fold (0.07 log units), on the low side; low and high end bracket the measured number.
By their numbers in this assay, from the lowest: compounds 2, 1 and 4 (each within the scatter of the next). At a limit, above all of these: compound 3.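

In this assay, three rings at the saturated chain carbon bound to a sulfur now give numbers that cannot be told apart: phenyl, 2-chlorophenyl and 2,6-difluorophenyl, with a 1.1-fold higher number from compound 1 to compound 4 (0.03 log units; within the scatter) and a 1.2-fold higher number from compound 2 to compound 4 (0.08 log units; within the scatter). Among the four compounds, only the 3-methoxyphenyl ring stands apart, and replacing it with 2,6-difluorophenyl gives an at least 2.8-fold lower number from compound 3 to compound 4 (0.45 log units; beyond the scatter), so a ring carrying fluorine behaves here like the plain and chlorinated rings and not like the methoxy one. That step is only a minimum size, since compound 3 has a limit of the assay and not a number: the limit of > 100000 nM in this assay, at which 1 of the 4 values shown sits.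

As far as these compounds go, it remains open whether the weaker result of compound 3 goes with the methoxy group itself or with where it sits on the ring. From the compounds shown here alone, it is also open whether any change at this position can give a clearly lower number than these three rings do, for instance an amine or a carboxylic acid on the ring, or a longer chain in place of the benzyl group.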